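The compounds below may be only part of what the source reports. "The series", "measured", "known", "first", "only" and "open" are said of these compounds alone.

In an ADME assay on Vero 76 cells (Chlorocebus sabaeus) for cytotoxicity, read by MTT assay, with a stated time of 96 h (a lower number here means that less compound is tolerated, a higher number that more compound is tolerated), compound 3 (`Cc1ccc(-c2nn(-c3ccccc3)cc2CNc2ccc(C(F)(F)F)cc2)cc1`) gives 45000 nM. This lies within the scatter of both other measured compounds: compound 2 (`Cc1ccc(-c2nn(-c3ccccc3)cc2CNc2ccccc2)cc1`) gives 52000 nM and compound 1 (`Clc1ccc(NCc2cn(-c3ccccc3)nc2-c2ccc(Cl)cc2)cc1`) gives 90000 nM.

The next comparison is compound 4 (`Cc1ccc(-c2nn(-c3ccccc3)cc2CNc2ccc(Cl)cc2)cc1`), with chloro in place of trifluoromethyl on an aromatic carbon. Among the measured compounds shown here, no measured step covers this exchange directly. The nearest is a 1.2-fold lower number from compound 2 to compound 3 (0.06 log units; within the scatter), where trifluoromethyl replaces hydrogen at the same place, and that step stays within the scatter. Compound 1 also carries 4-chlorophenyl on the amine nitrogen, but it differs from compound 4 elsewhere as well, so compound 1, at 90000 nM, is only a loose guide.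

No change beyond the scatter is therefore expected in this assay, and no direction can be assigned. The expected move is small, an estimated 1.2-fold higher number from compound 3 to compound 4 (0.09 log units; within the scatter). The estimated value for compound 4 is 55000 nM, with an expected range of 30000 nM to 100000 nM.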

Compound 4, half-maximal cytotoxic concentration: > 100000 nM
Compound 4: a limit, no number (the forecaster's own chance of this, stated with the estimate: 15%); at least 1.8-fold (0.25 log units) between middle value and limit.
By their numbers in this assay, from the lowest: compounds 3, 2 and 1 (each within the scatter of the next). At a limit, above all of these: compound 4.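

In this assay compound 4 gives > 100000 nM, which is a limit of the assay and not a number: the limit of > 100000 nM in this assay, at which 1 of the 4 values shown sits.

On this aromatic carbon, para to a large group, chloro in place of trifluoromethyl gives the only step shown that lies beyond the scatter, an at least 2.2-fold higher number from compound 3 to compound 4 (0.34 log units; beyond the scatter), whereas trifluoromethyl in place of hydrogen at the same place stayed within it, a 1.2-fold lower number from compound 2 to compound 3 (0.06 log units; within the scatter). The other two steps have floors within the scatter and so fix no change: an at least 1.9-fold higher number from compound 2 to compound 4 (0.28 log units; that floor lies within the scatter) and an at least 1.1-fold higher number from compound 1 to compound 4 (0.04 log units; that floor lies within the scatter).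

As far as these compounds go, with no number for compound 4, the true size of all three steps to it stays open. The compounds shown carry only hydrogen, chloro and trifluoromethyl at this place, so the response to an amine, a carboxylic acid or a methoxy group there remains open.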